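The compounds below may be only part of what the source reports. "The series", "measured", "known", "first", "only" and "open" are said of these compounds alone.

Within the data shown here, in a functional assay on HL-60 cells (Homo sapiens) for cytotoxicity, read by MTT assay, with a stated time of 72 h (on this read-out higher numbers stand for weaker inhibition and lower numbers for stronger inhibition), compound 2 `COc1cc(Nc2nc3ccccc3nc2S(=O)(=O)c2ccc(C)cc2)cc(OC)c1` gives 20 nM as the lower of the two numbers known so far. Compound 1 `Nc1cccc(Nc2nc3ccccc3nc2S(=O)(=O)c2ccccc2)c1` gives 1750 nM on the same read-out. The gap between these two compounds lies beyond the scatter. Compound 3 `Cc1ccc(S(=O)(=O)c2nc3ccccc3nc2Nc2cccc(N)c2)cc1` differs from compound 2 in one place, on a nitrogen on an aromatic ring, where 3-aminophenyl stands in place of 3,5-dimethoxyphenyl (3-aminophenyl in place of 3,5-dimethoxyphenyl on a nitrogen on an aromatic ring). Compound 1 also carries 3-aminophenyl and gives 1750 nM in this assay as the basis for expecting weaker inhibition. The expected step is large and upward (a 45-fold higher number from compound 2 to compound 3 (1.65 log units; beyond the scatter)), beyond the scatter. For compound 3 the estimate is 900 nM (expected range 250 nM to 3000 nM).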

Compound 3, half-maximal inhibitory concentration: 1080 nM
The estimate for compound 3 lay 1.2-fold (0.08 log units) below the measured number; measured number inside the range.
By their numbers in this assay, from the lowest: compound 2; then compounds 3 and 1 (each within the scatter of the next).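

In this assay, 3-aminophenyl in place of 3,5-dimethoxyphenyl on a nitrogen on an aromatic ring can now be read on its own, as a 54-fold higher number from compound 2 to compound 3 (1.73 log units; beyond the scatter), with the rest of the structure unchanged. Methyl in place of hydrogen on an aromatic carbon gives a 1.6-fold lower number from compound 1 to compound 3 (0.21 log units; within the scatter), so this change does not account for the large step. No evidence is available to explain why the change on the nitrogen has so large an effect. From the compounds shown here alone, it remains open how a ring carrying a single methoxy, or a hydroxyl or carboxylic acid in place of the amine, would read in this assay.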